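Configuration Decides Activity in Four Related Compounds

The source may report more compounds than this note shows. Statements on the series, on what has been measured and on what is new or still open speak of the compounds shown alone.

Compound 1, `CC(C)(C)C[C@H]1O[C@H](COCc2ccccc2)[C@@H](OCc2ccccc2)[C@H](OCc2ccccc2)[C@H]1O`: 12100 nM
Compound 2, `CC(C)C[C@H]1O[C@H](COCc2ccccc2)[C@@H](OCc2ccccc2)[C@H](OCc2ccccc2)[C@H]1O`: 13900 nM
Compound 3, `CC(C)(C)C[C@@H]1O[C@H](COCc2ccccc2)[C@@H](OCc2ccccc2)[C@H](OCc2ccccc2)[C@H]1O`: "not active" (no number reported), no number given

All values come from a functional assay on HL-60 cells (Homo sapiens) for antiproliferative activity, read by MTT assay; a lower number here means a stronger inhibitor, a higher number a weaker inhibitor. In this assay compound 1 gives 12100 nM, and compound 2 gives 13900 nM. The change from compound 1 to compound 2 is hydrogen in place of methyl on a saturated chain carbon bound to three saturated chain carbons, and it made a step of a 1.1-fold higher number from compound 1 to compound 2 (0.06 log units; within the scatter). In this assay compound 3 is reported as "not active" (no number reported) and carries no number; it differs from compound 1 by the two compounds have the same atoms and bonds and differ only in configuration as drawn: 1 of 5 stereo elements differ; a stereocentre at a saturated ring carbon is drawn R in compound 1 and S in compound 3, and its loss of activity rests on (the fact that compounds 1 and 3 differ only in the configuration as drawn).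

Compound 4, `CC(C)C[C@@H]1O[C@H](COCc2ccccc2)[C@@H](OCc2ccccc2)[C@H](OCc2ccccc2)[C@H]1O`, has not been measured. It stands to compound 3 as compound 2 stands to compound 1: the change is hydrogen in place of methyl on a saturated chain carbon bound to three saturated chain carbons, the same change that was made from compound 1 to compound 2. Since that change gave a step within the scatter in this assay, compound 4 is expected to behave like compound 3, and most likely to give no number at all. Should a number appear, compound 4 is estimated at 40000 nM, expected to lie between 15000 nM and 150000 nM.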

Compound 4, half-maximal inhibitory concentration: 8500 nM
The estimate for compound 4 lay 4.7-fold (0.67 log units) above the measured number; the measured number lies below the stated range.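

In this assay, within the data shown here, the same inversion at a saturated ring carbon that separates compound 1 from the not active compound 3 gave a 1.6-fold lower number from compound 2 to compound 4 (0.21 log units; within the scatter) on the isobutyl chain, and configuration is the only difference in that pair: the fact that compounds 2 and 4 differ only in the configuration as drawn. The change from neopentyl to isobutyl therefore does not carry unaltered from one core to the other: on the core of compound 1 it gave a 1.1-fold higher number from compound 1 to compound 2 (0.06 log units; within the scatter), whereas on the other core compound 4 gives 8500 nM and compound 3 has no number. This does not show how large the step on the second core is, since it cannot be read without a number for compound 3, and these two pairs give no cause for the difference.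

From the compounds shown here alone, it stays open whether a shorter or longer chain at this position would follow the neopentyl or the isobutyl pair. Going by these compounds, it is equally open how an amine or a carboxylic acid on that chain would behave on either core.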